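This account rests on a few compounds, and the source may have more. Where it says the series, first, only, none or still open, it means among the compounds named here.

Three compounds have been measured in a functional assay on HEK293 cells for positive allosteric modulation of metabotropic glutamate receptor 5 (Rattus norvegicus), read by fluorescence and calcium flux; on this read-out lower numbers stand for smaller maximal responses and higher numbers for larger maximal responses:

compound 1, `C[C@@H](NC(=O)c1ccc(C#Cc2ccccc2)cn1)C(C)(C)O`: 60.9%
compound 2, `C[C@@H](NC(=O)c1ccc(C#Cc2ccc(F)cc2)cn1)C(C)(C)O`: 66.2%
compound 3, `C[C@@H](NC(=O)c1ccc(C#Cc2cccnc2)cn1)C(C)(C)O`: 71.5%

Compound 3 has the highest of the three numbers. Its nearest neighbour is compound 2, and that gap, a number 5.3 percentage points higher from compound 2 to compound 3 (within the scatter), is within the scatter, so the two cannot be ordered. The furthest is compound 1, and a number 10.6 percentage points higher from compound 1 to compound 3 (beyond the scatter) is a modest step beyond the scatter.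

Compound 4, `C[C@@H](NC(=O)c1ccc(C#Cc2ccc(F)cn2)cn1)C(C)(C)O`, has not yet been measured in this assay. It differs from compound 3 in one place:

5-fluoropyridin-2-yl in place of pyridin-3-yl on a triple-bonded carbon

Two of the measured steps bear on this change. The addition of a fluoro group on an aromatic carbon, a number 5.3 percentage points higher from compound 1 to compound 2 (within the scatter), stayed within the scatter. The exchange of a phenyl for a pyridin-3-yl, a number 10.6 percentage points higher from compound 1 to compound 3 (beyond the scatter), gave a modest rise, while a number 5.3 percentage points higher from compound 2 to compound 3 (within the scatter) stayed within the scatter. Compound 4 keeps a pyridyl ring and adds a fluoro, so in this assay no step beyond the scatter is expected from compound 3, and the estimated step is a number 1.5 percentage points lower from compound 3 to compound 4 (within the scatter). Compound 4 is therefore expected to give about 70%, within a range from 55% to 85%.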

Compound 4, largest response reached (reported as efficacy), in percent of the reference or control that the assay uses: 64.6%
Compound 4: the middle estimate sits 5.4 percentage points above what was measured, within the range that was stated.
By their numbers in this assay, from the lowest: compounds 1, 4, 2 and 3 (each within the scatter of the next, the first and the last beyond it).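

In this assay, all three new steps at this place on a triple-bonded carbon stay within the scatter: a number 6.9 percentage points lower from compound 3 to compound 4 (within the scatter) and a number 1.6 percentage points lower from compound 2 to compound 4 (within the scatter) and also a number 3.7 percentage points higher from compound 1 to compound 4 (within the scatter). The last of these adds the most to the earlier picture: the exchange of phenyl for pyridin-3-yl gave a number 10.6 percentage points higher from compound 1 to compound 3 (beyond the scatter) and went beyond the scatter, whereas 5-fluoropyridin-2-yl in the same place does not, so a pyridyl ring as such does not carry a step beyond the scatter from phenyl. The change from pyridin-3-yl to 5-fluoropyridin-2-yl alters the pyridyl attachment and adds a fluoro in a single step, so these compounds do not separate the two contributions.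

Nothing measured here explains these steps. Still open, as far as these compounds go, is whether pyridin-2-yl without the fluoro, or pyridin-3-yl carrying a fluoro, would stay within the scatter of compound 3 or of compound 1, and what a methoxy group or an amine on the ring would do in this assay.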